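Urea analogues of a quinolone ester: one aryl group swapped

The source may hold more compounds than are shown below. What is called first, only, known or untested is meant among the compounds shown, and "the series" means these compounds.

Measured so far in a functional assay on UoC-B1 cells (Homo sapiens) for antiproliferative activity, with a stated time of 72 h; a higher number here means that more compound is needed for the effect, a lower number that less compound is needed:
Compound 1 `COc1ccc(-c2[nH]c3cc(OC)cc(OC)c3c(=O)c2I)cc1` gives "not determined" (no result reported).
Compound 2 `COC(=O)c1cc(=O)c2cc(NC(=O)Nc3ccc(Cl)c(Cl)c3)ccc2[nH]1` gives > 6350 nM, which is a limit of the assay rather than a number.
Compound 3 `COC(=O)c1cc(=O)c2cc(NC(=O)Nc3ccc(F)c(Cl)c3)ccc2[nH]1` gives > 6350 nM, again a limit of the assay rather than a number.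

Compound 3 therefore stands at the edge of what this assay can report: its value is a limit, and no single number is known for it. Among the compounds with values here, the one step among the measured compounds, a step that the two limits leave unreadable from compound 2 to compound 3, cannot be sized, because both ends sit at the limit of > 6350 nM in this assay, at which 2 of the 3 values shown sit. Compound 4 `COC(=O)c1cc(=O)c2cc(NC(=O)Nc3cccc(C(C)=O)c3)ccc2[nH]1` differs from compound 3 in one place: 3-acetylphenyl in place of 3-chloro-4-fluorophenyl on an amide-type nitrogen. Within the data shown here, no measured step touches this kind of change, so the only guidance is that both compounds carrying the shared core with a urea-linked aryl group ended at the limit. The step from compound 3 to compound 4 is thus expected to be unreadable as well, a step that the limit leaves unreadable from compound 3 to compound 4, with no direction beyond the scatter claimed. Compound 4 is expected to show 8000 nM in this assay, within a range from 2000 nM to 30000 nM, most likely reported again only as a limit.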

Compound 4, half-maximal effective concentration: > 8080 nM
Compound 4 ended at the assay's limit (the forecaster's own chance of this, stated with the estimate: 75%); middle value at least 1.0-fold (0.00 log units) away from the limit.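

Compound 2, compound 3 and compound 4 all end at limits of this assay rather than at numbers, and the steps from compound 2 and from compound 3 to compound 4 cannot be read. The compounds shown leave open whether any aryl group on the urea of the shared core gives a true number in this assay.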